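Propanoyl to Acetyl on Two Related Cytotoxic Cores

This account rests on a few compounds, and the source may have more. Where it says the series, first, only, none or still open, it means among the compounds named here.

Compound 1, `CCC(=O)c1ccc2c(c1O)[C@H]1c3c(ccc4c(=O)c(C)coc34)OC[C@H]1C(C)(C)O2`, in a functional assay on MCF7 cells (Homo sapiens) for cytotoxicity, read by MTT assay (a lower number here means a stronger inhibitor, a higher number a weaker inhibitor), gives > 100000 nM, which is a limit of the assay and not a number.
Compound 2, `CC(=O)c1ccc2c(c1O)[C@H]1c3c(ccc4c(=O)c(C)coc34)OC[C@H]1C(C)(C)O2`, in this assay gives > 100000 nM, again a limit rather than a number.
Compound 3, `CCC(=O)c1ccc2c(c1O)[C@@H]1c3c(ccc4c(=O)c(-c5ccccc5)c(C)oc34)OC[C@@H]1C(C)(C)O2`, in this assay gives 20500 nM.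

Compound 1 and compound 2 share a core and differ in one place: hydrogen in place of methyl on a saturated chain carbon bound to a carbonyl carbon. Both sit at a limit, so the step that the two limits leave unreadable from compound 1 to compound 2 cannot be read; all that can be said is that the two values show the same limit, in keeping with the limit of > 100000 nM in this assay, at which 2 of the 3 values shown sit.

Compound 3 carries a different core, and the difference between the two cores is not broken down here. Compound 4, `CC(=O)c1ccc2c(c1O)[C@@H]1c3c(ccc4c(=O)c(-c5ccccc5)c(C)oc34)OC[C@@H]1C(C)(C)O2`, is not yet measured. It stands to compound 3 as compound 2 stands to compound 1: hydrogen in place of methyl on a saturated chain carbon bound to a carbonyl carbon. The place of the change reads the same in both pairs, so this is the same kind of change on a second core.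

Since the measured pair gives no readable size for this change, the expectation for compound 4 rests mainly on the value of compound 3 itself. The step of a 1.5-fold higher number from compound 3 to compound 4 (0.17 log units; within the scatter) is estimated to be small, with the loss of one carbon expected to leave the compound in the same region as its parent. Compound 4 is therefore expected to give about 30000 nM in this assay, within a range from 10000 nM to 100000 nM.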

Compound 4, half-maximal inhibitory concentration: 11200 nM
Estimate against measurement, compound 4: 2.7-fold (0.43 log units) above; the measured number falls inside the stated range.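

On the core of compound 3, replacing propanoyl with acetyl gives a 1.8-fold lower number from compound 3 to compound 4 (0.26 log units; within the scatter) in this assay, so this pair shows no measurable effect of the change, which removes a single methyl and puts hydrogen in its place on a saturated chain carbon bound to a carbonyl carbon. Among the compounds shown here, on the core of compound 1, the same change gives no step that can be read, since compound 1 and compound 2 both sit at a limit of the assay rather than at a number: the limit of > 100000 nM in this assay, at which 2 of the 4 values shown sit. The two pairs therefore fit with each other without showing that the change carries over from one core to the other with the same size, and one readable pair is too little to make a rule for the series.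

The compounds shown leave open how the activity would respond to a longer chain such as butanoyl, or to a carboxylic acid or an amine carried on that chain in place of the methyl. They also leave open which part of the difference between the two cores matters, since no pair shown isolates any single part of it.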